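The source may hold more compounds than are shown below. What is called first, only, known or untested is meant among the compounds shown, and "the series" means these compounds.

Compound 1, `CCOC(=O)COCc1cc(-c2cc(Br)ccc2OC)no1`, was tested in a functional assay on BV-2 cells (Mus musculus) for inhibition, read by Griess assay, with a stated time of 24 h; a lower number here means a stronger inhibitor, a higher number a weaker inhibitor. Its result is a limit of the assay: compound 1 gives > 200000 nM. Compound 2, `C=CCc1ccc(OC)c(-c2cc(COCC(=O)OCC)on2)c1`, gives 25900 nM in this assay. The change between them, (allyl in place of bromo on an aromatic carbon), made a step of an at least 7.7-fold lower number from compound 1 to compound 2 (0.88 log units; beyond the scatter). Compound 3, `C=CCn1ccc(-c2cc(Br)ccc2OC)n1`, also returns only a limit: compound 3 gives > 200000 nM. How the core of compound 1 differs from that of compound 3 is not broken down here. Compound 4, `C=CCc1ccc(OC)c(-c2ccn(CC=C)n2)c1`, awaits measurement; it differs from compound 3 by allyl in place of bromo on an aromatic carbon, the same kind of change, though here the place is meta to a group of 8 heavy atoms rather than meta to a large group. The expected step is an at least 5.0-fold lower number from compound 3 to compound 4 (0.69 log units; beyond the scatter), set beside an at least 7.7-fold lower number from compound 1 to compound 2 (0.88 log units; beyond the scatter), with wide uncertainty because of the limit of > 200000 nM in this assay, at which 2 of the 3 values shown sit. Compound 4 is estimated at 40000 nM, between 8000 nM and 200000 nM.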

Compound 4, half-maximal inhibitory concentration: > 200000 nM
Compound 4 ended at the assay's limit (the forecaster's own chance of this, stated with the estimate: 40%); middle value at least 5.0-fold (0.69 log units) away from the limit.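

For the compounds shown here, compound 3 and compound 4 both sit at the limit of this assay, so no step between them can be read. The compounds shown leave open whether allyl in place of bromo changes anything on the core of compound 3.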